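The source may hold more compounds than are shown below. What is called first, only, known or untested is meant among the compounds shown, and "the series" means these compounds.

The measured compounds:
compound 1, `CN(C)c1ccc(C2CC(c3ccc(-n4cncn4)cc3)=NN2C(=O)CCCl)cc1`, -3.4%
compound 2, `CN(C)c1ccc(C2CC(c3ccc(-n4cncn4)cc3)=NN2C(=O)c2ccc(C(F)(F)F)cc2)cc1`, 7%

Among the measured compounds shown here, in a functional assay on HCC1806 cells (Homo sapiens) for inhibition, read by sulforhodamine B assay, tested at 10 uM (on this read-out higher numbers stand for more inhibition at the one concentration tested (going by the name of the read-out) and lower numbers for less inhibition), compound 2 gives 7%, the higher of the two numbers; compound 1 gives -3.4%, and the single measured step, a number 10.4 percentage points higher from compound 1 to compound 2 (beyond the scatter), put 4-(trifluoromethyl)phenyl in place of 2-chloroethyl on a carbonyl carbon. Compound 3, `CN(C)c1ccc(C2CC(c3ccc(-n4cncn4)cc3)=NN2C(=O)/C=C/c2ccccc2)cc1`, goes on from compound 2: 2-phenylethenyl in place of 4-(trifluoromethyl)phenyl on a carbonyl carbon. The change sits on the same carbonyl carbon, but it exchanges one group holding a six-membered aromatic ring of carbon only for another, and the step from compound 1 to compound 2 bears on it only by showing that a change of group at this place moved the number modestly. For the measured compounds named here, no measured step exchanges two such groups, so the expected step in this assay, no change at the digits printed from compound 2 to compound 3 (within the scatter), is none beyond the scatter. Compound 3 is therefore expected to give 7%, in a range from -8% to 22%.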

Compound 3, a percentage reported as inhibition, at one concentration (the size of the read-out at that concentration, not a potency): -3.7%
Compound 3: middle estimate off by 10.7 percentage points, on the high side; low and high end bracket the measured number.
By their numbers in this assay, from the lowest: compounds 3 and 1 (each within the scatter of the next); then compound 2.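

At this carbonyl carbon, exchanging one group holding a six-membered aromatic ring of carbon only for another gave a number 10.7 percentage points lower from compound 2 to compound 3 (beyond the scatter) in this assay, so sharing such a ring did not keep the number in place. Among the compounds shown here, replacing 2-chloroethyl with 2-phenylethenyl gave a number 0.3 percentage points lower from compound 1 to compound 3 (within the scatter), which leaves those two groups indistinguishable here and makes 4-(trifluoromethyl)phenyl the only one of the three groups whose number stands apart from both others. No measurement given here accounts for these differences.

Still open, going by these compounds, is which part of the change matters, the loss of the trifluoromethyl group or the entry of the double bond; a plain phenyl group on the carbonyl carbon would separate the two. On these data alone, how an amine or a carboxylic acid at this place would read also remains open.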